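Swapping an Ester Tail for a Quinoline Group

A few compounds are considered here, and "the series" means these few. Any claim that something is new, unique, unknown or untested is made for them only; others in the source may bear on it.

Two measured compounds share one core. Compound 1 `CC1=C(C(=O)OCc2ccccc2)C(c2ccc(Cl)cc2Cl)NC(=O)N1CCCC(=O)OCc1ccccc1` gives in an ADME assay on MCF7 cells (Homo sapiens) for cytotoxicity, read by CellTiter-Glo, with a stated time of 24 h (a lower number here means a stronger inhibitor of growth, a higher number a weaker inhibitor of growth), only a limit of the assay, > 100000 nM. Compound 2 `C/C=C/COC(=O)CCCN1C(=O)NC(c2ccc(Cl)cc2Cl)C(C(=O)OCc2ccccc2)=C1C` likewise gives only a limit in this assay, > 100000 nM. Compound 2 therefore stands where both values shown sit (the limit of > 100000 nM in this assay, at which 2 of the 2 values shown sit). Among the compounds with values here, the one measured step, a step that the two limits leave unreadable from compound 1 to compound 2, remains unreadable and so gives no guidance. Compound 3 `CC1=C(C(=O)OCc2ccccc2)C(c2ccc(Cl)cc2Cl)NC(=O)N1CCCC(=O)OCc1ccc2ccccc2n1` differs from compound 2 by quinolin-2-yl in place of prop-1-en-1-yl on a saturated chain carbon bound to an oxygen next to a carbonyl group. With no readable step to lean on, no change beyond the scatter is expected, so the estimated step is a number no higher from compound 2 to compound 3 (the limit leaves the size open). Compound 3 is thus expected to give about 100000 nM in this assay, within 30000 nM to 300000 nM, most likely again only as a limit.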

Compound 3, concentration for 50% growth inhibition: > 100000 nM
Compound 3 ended at the assay's limit; the forecaster's own chance of this, stated with the estimate: 75%; the middle value sits exactly at the limit.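

No step can be read among compound 1, compound 2 and compound 3, as each gives only a limit: the limit of > 100000 nM in this assay, at which 3 of the 3 values shown sit. What these compounds leave open is how strongly any of them inhibits growth, and whether changing the ester tail alters that at all.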